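The compounds below may be only part of what the source reports. "The series", "measured", "known", "first", "only" and "open" are said of these compounds alone.

In a functional assay on HO8910 cells (Homo sapiens) for inhibition, read by MTT assay, with a stated time of 24 h, tested at 10 ug/mL (on this read-out lower numbers stand for less inhibition of growth and higher numbers for more inhibition of growth at the one concentration tested), compound 1 (`O=C(CCCCC(S)CCS)Nc1ccc(Cl)cc1`) is reported as "not active" (no number reported), without a number. Compound 2 (`O=C(CCCCC(S)CCS)Nc1ccc(F)cc1`) gives 6.81%, and compound 3 (`O=C(CCCCC(S)CCS)Nc1ccc(OC(F)(F)F)cc1`) gives 6.11%. For the measured compounds named here, compound 3 therefore stands within the scatter of compound 2, the only other compound with a number. Compound 4 (`COc1ccc(NC(=O)CCCCC(S)CCS)cc1`) differs from compound 3 in one place: methyl in place of trifluoromethyl on an oxygen on an aromatic ring. This puts methoxy where trifluoromethoxy stood. Going by the values given here, the one measured step that bears on this change, with trifluoromethoxy in place of fluoro on an aromatic carbon, is a number 0.7 percentage points lower from compound 2 to compound 3 (within the scatter). It offers no ground for expecting a real shift in this assay. The expected step is a number 0.1 percentage points lower from compound 3 to compound 4 (within the scatter), which is none beyond the scatter. Compound 4 is estimated at 6%, with an expected range of 0% to 14%.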

Compound 4, percent growth inhibition at one concentration: 4.14%
Compound 4: middle estimate off by 1.9 percentage points, on the high side; the measured number falls inside the stated range.
By their numbers in this assay, from the lowest: compounds 4, 3 and 2 (each within the scatter of the next).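

In this assay methyl in place of trifluoromethyl on an oxygen on an aromatic ring gives a number 2 percentage points lower from compound 3 to compound 4 (within the scatter) and so does not separate the two compounds. Methoxy in place of fluoro on an aromatic carbon gives a number 2.7 percentage points lower from compound 2 to compound 4 (within the scatter) and thus fluoro, trifluoromethoxy and methoxy all stand within the scatter of one another on this read-out. No measurement shown here offers an explanation for this result.

Going by these compounds, whether an amine or a carboxylic acid on the aromatic ring would give a number beyond the scatter stays open. So does the effect of a longer chain on the oxygen.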